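A few compounds are considered here, and "the series" means these few. Any claim that something is new, unique, unknown or untested is made for them only; others in the source may bear on it.

Values in an ADME assay on BJ cells (Homo sapiens) for cytotoxicity, with a stated time of 72 h; a lower number here means that less compound is needed, a higher number that more compound is needed for the effect:
Compound 1 `COc1cccc(-c2nc3c(c(C)nn3-c3ccccc3)c(-c3ccccc3O)c2C#N)c1`: > 23000 nM, a limit.
Compound 2 `Cc1nn(-c2ccccc2)c2nc(-c3ccc4ccccc4c3)c(C#N)c(-c3ccccc3O)c12`: > 20000 nM, a limit.
Compound 3 `Cc1nn(-c2ccccc2)c2nc(-c3ccc(I)cc3)c(C#N)c(-c3ccccc3O)c12`: 19000 nM.

Compound 3 is the only one of the three with a number rather than a limit. Compound 4 `Cc1nn(-c2ccccc2)c2nc(-c3ccc([N+](=O)[O-])cc3)c(C#N)c(-c3ccccc3O)c12` carries nitro in place of iodo on an aromatic carbon, para to a large group: nitro in place of iodo on an aromatic carbon. Three measured steps exchange the whole group that carries the iodo. They are an at least 1.2-fold lower number from compound 1 to compound 3 (0.08 log units; that floor lies within the scatter), an at least 1.0-fold lower number from compound 2 to compound 3 (0.02 log units; that floor lies within the scatter) and a step that the two limits leave unreadable from compound 1 to compound 2. None shows a readable change beyond the scatter, and none involves nitro. The expected change is a 1.1-fold higher number from compound 3 to compound 4 (0.02 log units; within the scatter), not beyond the scatter. Compound 4 is expected at about 20000 nM, with an estimated range of 9000 nM to 40000 nM.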

Compound 4, half-maximal effective concentration: > 20000 nM
Compound 4: only a limit was reported; the forecaster's own chance of this, stated with the estimate: 45%; the middle value sits exactly at the limit.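

Compound 4 gives only a limit in this assay: the limit of > 20000 nM in this assay, at which 2 of the 4 values shown sit. Within the data shown here, this is the first change of the small group alone rather than the whole group carrying it, and nitro in place of iodo gives an at least 1.0-fold higher number from compound 3 to compound 4 (0.02 log units; that floor lies within the scatter), so this place shows no readable change beyond the scatter. The steps to compound 4 from compound 1 and from compound 2 cannot be read, as both ends are limits. As far as these compounds go, how far the true value of compound 4 lies past its limit stays open. From the compounds shown here alone, whether an amine or a carboxylic acid at this place would give a readable change in this assay also stays open.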